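The compounds below may be only part of what the source reports. "The series", "measured", "known", "first", "only" and "open" are said of these compounds alone.

Working notes on the series. In a functional assay on HUVEC cells (Homo sapiens) for inhibition, with a stated time of 4 days (on this read-out higher numbers stand for weaker inhibition and lower numbers for stronger inhibition), compound 3 (`COc1ccc(C(N)=O)cc1/C=C/c1ccccc1`) gives 2400 nM, within the scatter of compound 1 (`COc1ccc(C(C)=O)cc1COc1cccc(C)c1`) at 2800 nM. Compound 2 (`COc1ccc(C(N)=O)cc1/C=C/c1ccc(Cl)cc1`) gives a far lower number, 87 nM.

The next change leads to compound 4 (`COc1ccc(C(N)=O)cc1/C=C/c1ccc(C(C)(C)C)cc1`): tert-butyl in place of hydrogen on an aromatic carbon, para to a large group.

Among the compounds with values here, one measured step bears on this change: a 28-fold higher number from compound 2 to compound 3 (1.44 log units; beyond the scatter), large and beyond the scatter, with hydrogen in place of chloro on an aromatic carbon. Read in reverse, it shows that replacing hydrogen with chloro goes with a much lower number. Tert-butyl is a different group, and no measured compound carries it, so a smaller shift in the same direction is expected.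

The expected shift is a 6.0-fold lower number from compound 3 to compound 4 (0.78 log units; beyond the scatter), toward stronger inhibition. For compound 4 the estimated value is 400 nM, with an expected range from 60 nM to 2500 nM.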

Compound 4, half-maximal inhibitory concentration: 370 nM
Compound 4: the middle estimate sits 1.1-fold (0.03 log units) above what was measured; measured number inside the range.
By their numbers in this assay, from the lowest: compound 2; then compound 4; then compounds 3 and 1 (each within the scatter of the next).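

In this assay the lower number seen with chloro is not unique to that group: on an aromatic carbon para to a large group, tert-butyl with its 4 heavy atoms also gives a step beyond the scatter, a 6.5-fold lower number from compound 3 to compound 4 (0.81 log units; beyond the scatter) for tert-butyl in place of hydrogen. The two groups do not stand level, however, with a 4.3-fold higher number from compound 2 to compound 4 (0.63 log units; beyond the scatter) for tert-butyl in place of chloro, so the size of the shift from hydrogen depends on which group enters. The data shown offer no measured basis for explaining this order of chloro, tert-butyl and hydrogen.

From the compounds shown here alone, whether an amine, a carboxylic acid or a trifluoromethyl group at this position would fall with chloro, with tert-butyl or elsewhere stays open. Also open, going by these compounds, is whether either group would lower the number on the core of compound 1.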